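Adding a chlorine to the urea tail of compound 1

This account rests on a few compounds, and the source may have more. Where it says the series, first, only, none or still open, it means among the compounds named here.

Compound 1, `O=C(Nc1cccc(-n2cc(-c3ccncc3)c(-c3ccc(Cl)c(O)c3)n2)c1)Nc1cccc(C(F)(F)F)c1`, is a urea-linked compound built on a shared core. In a functional assay on NCI-H23 cells (Homo sapiens) for inhibition, read by sulforhodamine B assay, with a stated time of 48 h (on this read-out lower numbers stand for stronger inhibition of growth and higher numbers for weaker inhibition of growth), compound 1 gives > 32500 nM, which is a limit of the assay rather than a number. Compound 2, `COc1cc(-c2nn(-c3cccc(NC(=O)Nc4cccc(C(F)(F)F)c4)c3)cc2-c2ccncc2)ccc1Cl`, gives 3410 nM in this assay. Compound 3, `COc1cc(-c2nn(-c3cccc(NC(=O)c4ccc(Cl)c(C(F)(F)F)c4)c3)cc2-c2ccncc2)ccc1Cl`, gives > 32500 nM in this assay, a limit again. Within the data shown here, the step of an at least 9.5-fold lower number from compound 1 to compound 2 (0.97 log units; beyond the scatter) and the step of an at least 9.5-fold higher number from compound 2 to compound 3 (0.97 log units; beyond the scatter) are the only measured steps, and both move the number by a large amount; the limit of > 32500 nM in this assay, at which 2 of the 3 values shown sit, sets the ceiling seen for compound 1 and compound 3. Compound 4, `O=C(Nc1cccc(-n2cc(-c3ccncc3)c(-c3ccc(Cl)c(O)c3)n2)c1)Nc1ccc(Cl)c(C(F)(F)F)c1`, differs from compound 1 by chloro in place of hydrogen on an aromatic carbon. Among the measured compounds shown here, neither measured step touches this position, so no measured step bears directly on it. Compound 4 is therefore expected to stay near where compound 1 sits, with the step of an at least 1.3-fold lower number from compound 1 to compound 4 (0.11 log units; that floor lies within the scatter) estimated as none beyond the scatter. The estimate for compound 4 in this assay is 25000 nM, between 6000 nM and 32500 nM.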

Compound 4, concentration for total growth inhibition: 3330 nM
The estimate for compound 4 lay 7.5-fold (0.88 log units) above the measured number, outside the stated range (below it).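

In this assay, a single chlorine on the ring of the urea tail, ortho to a trifluoromethyl group and para to a large group, gives an at least 9.7-fold lower number from compound 1 to compound 4 (0.98 log units; beyond the scatter), so this position is far from silent. Among the earlier compounds, the only downward step was an at least 9.5-fold lower number from compound 1 to compound 2 (0.97 log units; beyond the scatter), with methyl in place of hydrogen on an oxygen on an aromatic ring; the urea tail now offers a second single change that brings the number down. The full size of the new step cannot be read, because compound 1 stands at a limit of the assay rather than at a number: the limit of > 32500 nM in this assay, at which 2 of the 4 values shown sit.

Going by these compounds, whether a bromine atom or an amine at this place would bring the number down as chlorine does remains open. Also open, on these data alone, is whether the chlorine and the methyl on the oxygen would add up in one compound.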